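The compounds below may be only part of what the source reports. "The series", "measured", "known", "first", "only" and "open" are said of these compounds alone.

Compound 1, `CNc1cc(C)c2cc(NC(=O)c3ccc(Cl)c(Cl)c3)ccc2n1`: 6350 nM
Compound 2, `CCN1CCN(c2cc(C)c3cc(NC(=O)c4ccc(Br)cc4)ccc3n2)CC1`: 6310 nM

Both compounds were tested in a functional assay on SK-BR-3 cells (Homo sapiens) for antiproliferative activity, read by MTT assay, with a stated time of 72 h; a higher number here means a weaker inhibitor, a lower number a stronger inhibitor. Compound 1 gives 6350 nM, and compound 2 gives 6310 nM. These two numbers fall within the usual scatter of each other, so compound 2 stands at the same level as compound 1, and neither can be called the stronger. The two compounds differ in several places at once, so no single change can be read from this pair.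

Compound 3, `CCN1CCN(c2cc(C)c3cc(NC(=O)c4ccccc4OC)ccc3n2)CC1`, has not yet been measured. It differs from compound 2 in one place: 2-methoxyphenyl in place of 4-bromophenyl on a carbonyl carbon. Going by the values given here, no pair of measured compounds shows what such a change does in this assay, so there is no direct guide. The step is expected to be a 1.3-fold higher number from compound 2 to compound 3 (0.10 log units; within the scatter), small, and if anything toward a weaker inhibitor, since both measured values sit close together. Compound 3 is therefore estimated at 8000 nM, in a range from 3000 nM to 25000 nM.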

Compound 3, half-maximal inhibitory concentration: 15700 nM
Compound 3: middle estimate off by 2.0-fold (0.29 log units), on the low side, within the range that was stated.
By their numbers in this assay, from the lowest: compounds 2 and 1 (each within the scatter of the next); then compound 3.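

In this assay, the group on the carbonyl carbon proves able to move the number: 2-methoxyphenyl in place of 4-bromophenyl gives a 2.5-fold higher number from compound 2 to compound 3 (0.40 log units; beyond the scatter), a modest step beyond the scatter and toward a weaker inhibitor. Going by these compounds alone, this is the first change at a single place that can be read, since compound 1 and compound 2 differ in several places at once and their matching values could not speak for any one group. Nothing among the data given accounts for this step.

The change replaces the bromine with a methoxy group and also moves the substituent from the 4-position to the 2-position, so these two parts of the step remain unseparated; 4-methoxyphenyl or 2-bromophenyl on the same carbonyl carbon would tell them apart. Also open, from the compounds shown here alone, is whether a stronger inhibitor can be reached at this place, for instance with an aminophenyl or carboxyphenyl group, and whether the step would keep its size on the core of compound 1.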